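Swapping chloro for methoxy: cytotoxicity of two bis-benzylidene cyclohexanones

A few compounds are considered here, and "the series" means these few. Any claim that something is new, unique, unknown or untested is made for them only; others in the source may bear on it.

Measured compounds:
compound 1, `COc1cc(/C=C2\CCC/C(=C\c3ccc([N+](=O)[O-])cc3)C2=O)ccc1O`, 171000 nM
compound 2, `O=C1/C(=C/c2ccc(Cl)cc2)CCC/C1=C\c1ccc([N+](=O)[O-])cc1`, 332000 nM

In a functional assay on HPLF cells (Homo sapiens) for cytotoxicity (on this read-out higher numbers stand for lower toxicity in this test and lower numbers for higher toxicity in this test), compound 2 gives 332000 nM, the higher of the two numbers, with compound 1 at 171000 nM; the gap a 1.9-fold higher number from compound 1 to compound 2 (0.29 log units; within the scatter) is within the scatter, so the two are not separated. Compound 3, `COc1ccc(/C=C2\CCC/C(=C\c3ccc([N+](=O)[O-])cc3)C2=O)cc1`, is not yet measured. It differs from compound 2 by methoxy in place of chloro on an aromatic carbon. Among the measured compounds shown here, the only measured step that bears on this change is the one from compound 1 to compound 2, where a larger swap of the aryl group on the same position gave a 1.9-fold higher number from compound 1 to compound 2 (0.29 log units; within the scatter). On that basis no step beyond the scatter is expected for compound 3 in this assay, and the expected step is a 1.3-fold lower number from compound 2 to compound 3 (0.11 log units; within the scatter). The estimate for compound 3 is 260000 nM, with a range from 120000 nM to 550000 nM.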

Compound 3, half-maximal cytotoxic concentration: > 400000 nM
Compound 3: no number, only a limit; the forecaster's own chance of this, stated with the estimate: 10%; middle value at least 1.5-fold (0.18 log units) from the limit.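

In this assay compound 3 reads as a limit of the assay and not as a number: the limit of > 400000 nM in this assay, at which 1 of the 3 values shown sits. Among the compounds shown here, replacing 4-hydroxy-3-methoxyphenyl with 4-methoxyphenyl gives an at least 2.3-fold higher number from compound 1 to compound 3 (0.36 log units; beyond the scatter), the first step at this position that lies beyond the scatter, so the aryl group here can shift this read-out measurably. The change of chloro to methoxy gives an at least 1.2-fold higher number from compound 2 to compound 3 (0.08 log units; that floor lies within the scatter), and as that floor lies within the scatter, the change is not shown to separate the two compounds.

The limit leaves open how large either step really is, and the compounds shown cannot tell which part of the difference in the aryl group carries the step beyond the scatter. Also open, as far as these compounds go, is how an amine or a carboxylic acid on that aromatic carbon would read in this assay.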